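Swapping Chloro for Propoxy: What to Expect

The compounds below may be only part of what the source reports. "The series", "measured", "known", "first", "only" and "open" are said of these compounds alone.

Measured so far:
- compound 2 `Oc1ccccc1CNc1ccc(-c2ccc(Cl)cc2)cc1` gives 2390 nM in a functional assay on Jurkat cells (Homo sapiens) for activation, with a stated time of 24 h; a lower number here means that less compound is needed, a higher number that more compound is needed for the effect
- compound 3 `Cc1cccc(-c2ccc(NCc3ccccc3O)cc2)c1` gives 9190 nM in this assay
- compound 1 `CN1CCN(c2ccc(NCc3ccccc3O)cc2)CC1` is reported only as "not active" (no number reported) in this assay, with no number

Compound 2 has the lowest number of the two that are reported. Going by the values given here, the only step measured between neighbours is a 3.8-fold higher number from compound 2 to compound 3 (0.58 log units; beyond the scatter), where 3-methylphenyl replaces 4-chlorophenyl on an aromatic carbon; it is a modest rise and lies beyond the scatter. Compound 1, whose shared core carries a different group and shows no activity, adds no number to compare.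

Compound 4 `CCCOc1ccc(-c2ccc(NCc3ccccc3O)cc2)cc1` is not yet measured. It differs from compound 2 by propoxy in place of chloro on an aromatic carbon, on an aromatic carbon of a six-membered aromatic ring of carbon only, para to a large group.

Among the compounds with values here, no measured step changes the group at exactly this place, so the guide is indirect: the one change at the outer ring, from compound 2 to compound 3, made the number go up. The expectation for the step from compound 2 to compound 4 is therefore a rise of similar or smaller size, a 1.9-fold higher number from compound 2 to compound 4 (0.27 log units; within the scatter), with a real chance of no change beyond the scatter. Compound 4 is estimated at 4500 nM, in the range 1200 nM to 16000 nM.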

Compound 4, half-maximal effective concentration: "not active" (no number reported)
Compound 4: no number reported; there is nothing to compare the estimate with.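

Going by these compounds alone, compound 4 gives "not active" (no number reported) in this assay and therefore offers no number to set against compound 2, so no step between these two compounds can be read. Nothing shown here accounts for this result. The compounds shown leave open how far propoxy in place of chloro shifts the number, if compound 4 has any measurable effect at all.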